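The source may report more compounds than this note shows. Statements on the series, on what has been measured and on what is new or still open speak of the compounds shown alone.

Compound 1, `O=C(/C=C/c1ccc2c(c1)B(O)OC2)c1ccc(Br)cc1`, gives 9900 nM in a functional assay on HCT-116 cells (Homo sapiens) for cytotoxicity, read by MTT assay, with a stated time of 48 h; a higher number here means a weaker inhibitor, a lower number a stronger inhibitor. Its only companion, compound 2, `O=C(/C=C/c1ccc2c(c1)B(O)OC2)c1ccc(C(F)(F)F)cc1`, gives 6300 nM in this assay, so compound 1 holds the higher of the two numbers, though the difference, a 1.6-fold lower number from compound 1 to compound 2 (0.20 log units; within the scatter), does not separate the two. Compound 3, `O=C(/C=C/c1ccc2c(c1)B(O)OC2)c1ccccc1O`, differs from compound 1 in one place: 2-hydroxyphenyl in place of 4-bromophenyl on a carbonyl carbon. Among the compounds with values here, the single measured step swaps one group for another on an aromatic carbon of the ring attached to the carbonyl, while the change to compound 3 exchanges that whole ring substituent; the step therefore bears on it only loosely, and its small size gives no reason to expect a move beyond the scatter. Compound 3 is thus expected to sit near compound 1, with a 1.3-fold lower number from compound 1 to compound 3 (0.12 log units; within the scatter), at an estimated 7500 nM within a range of 2500 nM to 22000 nM.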

Compound 3, half-maximal inhibitory concentration: 77900 nM
The estimate for compound 3 lay 10-fold (1.02 log units) below the measured number; the whole stated range lies below it.
By their numbers in this assay, from the lowest: compounds 2 and 1 (each within the scatter of the next); then compound 3.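

Within the data shown here, on the carbonyl carbon, putting 2-hydroxyphenyl in place of 4-bromophenyl gives the first change here that clearly moves the number in this assay, with a 7.9-fold higher number from compound 1 to compound 3 (0.90 log units; beyond the scatter), whereas the earlier ring change, a 1.6-fold lower number from compound 1 to compound 2 (0.20 log units; within the scatter), stayed within the scatter. This position is therefore not indifferent to what its ring carries, at least for this change, in which the heavy-atom count stays the same and a hydrogen-bond donor and acceptor are counted only on the entering group. Nothing available explains the rise in the number for compound 3.

The swap removes the bromine and brings in the hydroxyl at a different ring position in one move, so the compounds shown cannot tell which of these goes with the higher number. On these data alone, whether an amine or a methoxy group on this ring would give a number near that of compound 3 or that of compound 1 also remains open.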